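Benzyl ether series: 3-fluoro to 3-methyl

The source may hold more compounds than are shown below. What is called first, only, known or untested is meant among the compounds shown, and "the series" means these compounds.

Of the compounds shown here, two have numbers so far in a functional assay on aorta (Rattus norvegicus, strain Sprague-Dawley); on this read-out higher numbers stand for an effect only at larger amounts of compound and lower numbers for an effect already at smaller amounts. Compound 1 `Cc1nn(-c2ccccc2)c2nc(OCc3ccccc3F)c(-c3nc(N)cc(N)n3)cc12` gives 2200 nM, and compound 2 `Cc1nn(-c2ccccc2)c2nc(OCc3cccc(F)c3)c(-c3nc(N)cc(N)n3)cc12` gives 360 nM, the lower of the two. Among the compounds with values here, the only measured step is a 6.1-fold lower number from compound 1 to compound 2 (0.79 log units; beyond the scatter), with 3-fluorophenyl in place of 2-fluorophenyl.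

Compound 3 `Cc1cccc(COc2nc3c(cc2-c2nc(N)cc(N)n2)c(C)nn3-c2ccccc2)c1` keeps the shared core and differs from compound 2 in one group: methyl in place of fluoro on an aromatic carbon. This is methyl in place of fluoro on an aromatic carbon, meta to a large group, so 3-fluorobenzyl becomes 3-methylbenzyl.

The measured step bears on this only indirectly. It shows that the number in this assay can shift beyond the scatter when the fluoro changes place on this ring, whereas here the place is kept and the group is exchanged. Within the data shown here, no measured step exchanges fluoro for methyl, so the anchor is compound 2 at 360 nM, and no step beyond the scatter is expected in either direction. The expected change is a 1.3-fold higher number from compound 2 to compound 3 (0.10 log units; within the scatter). For compound 3 the estimated value is 450 nM, with an expected range of 130 nM to 1500 nM.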

Compound 3, half-maximal effective concentration: 990 nM
For compound 3 the middle estimate is 2.2-fold (0.34 log units) below the measured one; low and high end bracket the measured number.
By their numbers in this assay, from the lowest: compound 2; then compound 3; then compound 1.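

The exchange of fluoro for methyl at an unchanged place gives a step beyond the scatter in this assay (a 2.8-fold higher number from compound 2 to compound 3 (0.44 log units; beyond the scatter)), so the number at this position follows the identity of the group as well as its place on the ring. The 3-methylbenzyl ether also keeps a step beyond the scatter from the 2-fluorobenzyl ether (a 2.2-fold lower number from compound 1 to compound 3 (0.35 log units; beyond the scatter)), which puts compound 3 between the two fluoro compounds, with the 3-fluorobenzyl ether of compound 2 the lowest of the three. No measurement shown here accounts for fluoro and methyl parting in this way.

On these data alone, two groups at this place cannot separate the possible trends, so it remains open how chloro, methoxy, trifluoromethyl or a plain unsubstituted benzyl ether would fall relative to compound 2 and compound 3. As far as these compounds go, it is also open whether methyl responds to a change of place on the ring as fluoro does, since the step between compound 1 and compound 2 is the only one of that kind and concerns fluoro alone.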